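The source may hold more compounds than are shown below. What is called first, only, known or untested is meant among the compounds shown, and "the series" means these compounds.

Going by the values given here, compound 2 `CCOC(=O)c1cnc(NCc2ccc(F)cc2)n2nc(-c3ccco3)nc12` is the only member of the series with a number in a functional assay on CHO cells for antagonist activity at adenosine receptor A2b (Homo sapiens); on this read-out higher numbers stand for weaker inhibition and lower numbers for stronger inhibition; in this assay compound 2 gives 1970 nM. Compound 1 `CCOC(=O)c1cnc(NCC2CCCCC2)n2nc(-c3ccco3)nc12` stands at a limit of the assay, as compound 1 gives > 10000 nM in this assay, which is the limit of > 10000 nM in this assay, at which 1 of the 2 values shown sits. Among the compounds with values here, the single measured step runs from the saturated cyclohexyl to the aromatic ring: an at least 5.0-fold lower number from compound 1 to compound 2 (0.70 log units; beyond the scatter). Compound 3 `CCOC(=O)c1cnc(NCCOC)n2nc(-c3ccco3)nc12` goes the other way: methoxymethyl in place of 4-fluorophenyl on a saturated chain carbon bound to a nitrogen on an aromatic ring. Within the data shown here, the only step on record suggests that giving up the aromatic ring on this carbon costs potency, and the methoxymethyl of compound 3 is shorter still and carries no ring. The step is therefore expected to run back toward the weaker side, with a 3.6-fold higher number from compound 2 to compound 3 (0.55 log units; beyond the scatter) as the estimate. Compound 3 is estimated at 7000 nM in this assay, within a range of 2000 nM to 25000 nM, and a limit rather than a number would not surprise.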

Compound 3, inhibition constant: > 10000 nM
Compound 3: a limit, no number; the forecaster's own chance of this, stated with the estimate: 40%; middle value at least 1.4-fold (0.15 log units) from the limit.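

In this assay, the aromatic ring on this saturated chain carbon now has a second non-aromatic replacement to set against it: an at least 5.0-fold higher number from compound 2 to compound 3 (0.70 log units; beyond the scatter). With methoxymethyl, a group with no ring, joining cyclohexyl, only compound 2 with its 4-fluorophenyl gives a number, and none of the three compounds goes against this. Compound 1 and compound 3 both stand at a limit of the assay, so the step between them cannot be read and the two non-aromatic groups cannot be ranked: the limit of > 10000 nM in this assay, at which 2 of the 3 values shown sit.

On these data alone, whether any aromatic ring on this carbon is enough, or the fluorine of the 4-fluorophenyl also counts, stays open, and an unsubstituted phenyl or a pyridyl here would separate the two. As far as these compounds go, how an amine or a longer chain carrying a phenyl would read also remains unknown.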